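Removing a Methyl from the Outer Ring: What to Expect

A few compounds are considered here, and "the series" means these few. Any claim that something is new, unique, unknown or untested is made for them only; others in the source may bear on it.

Of the compounds shown here, three sharing one core have been measured in a toxicity assay on MCF7 cells (Homo sapiens) for inhibition, with a stated time of 48 h; on this read-out lower numbers stand for stronger inhibition of growth and higher numbers for weaker inhibition of growth. Compound 1 `CC1=C(C(=O)OCc2ccccc2)C(c2ccc(-c3ccccc3C)cc2)NC(=O)N1Cc1ccc(-c2nnn[nH]2)cc1` gives 140000 nM in this assay. Compound 2 `CC1=C(C(=O)OCc2ccccc2)C(c2ccc(-c3ccccc3C)cc2)NC(=O)N1CCCCCc1nnn[nH]1` gives 72000 nM, and compound 3 `CC1=C(C(=O)OCc2ccccc2)C(c2ccc(-c3ccccc3C)cc2)NC(=S)N1Cc1ccc(-c2nnn[nH]2)cc1` gives 160000 nM. Among these three numbers compound 1 stands second highest; its nearest neighbour is compound 3, and the two values lie within the scatter of each other, so nothing can be said about their order. Going by the values given here, the one step between compounds that differ in a single place is a 1.9-fold lower number from compound 1 to compound 2 (0.29 log units; within the scatter), and it too stays within the scatter.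

Compound 4 `CC1=C(C(=O)OCc2ccccc2)C(c2ccc(-c3ccccc3)cc2)NC(=O)N1Cc1ccc(-c2nnn[nH]2)cc1` is not yet measured. It differs from compound 1 by hydrogen in place of methyl on an aromatic carbon; on the outer ring of the biaryl group this reads as 2-methylphenyl to phenyl. Among the compounds with values here, none of the measured steps touches this part of the molecule, so no measured step bears directly on it. What the measured steps do show is that changes elsewhere in the molecule, both at the group on the ring nitrogen and at the carbonyl sulfur exchange, left the number within the scatter. The step is therefore expected to be no change at the digits printed from compound 1 to compound 4 (within the scatter), with no change beyond the scatter. Compound 4 is thus estimated at 140000 nM, in a range from 60000 nM to 320000 nM.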

Compound 4, concentration for 50% growth inhibition: 160000 nM
The estimate for compound 4 lay 1.1-fold (0.06 log units) below the measured number; the measured number falls inside the stated range.
By their numbers in this assay, from the lowest: compounds 2, 1, 3 and 4 (each within the scatter of the next, the first and the last beyond it).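

Removing the methyl from its place ortho to a large group on the outer ring gives a 1.1-fold higher number from compound 1 to compound 4 (0.06 log units; within the scatter) in this assay. Going by these compounds alone, this is the first measured step at this position, and it shows that 2-methylphenyl and phenyl cannot be told apart by this read-out, so compound 1 and compound 4 cannot be placed in any order. No measurement of any property bears on this result, so no explanation for it can be offered.

The compounds shown leave open whether a different group at this place, such as a chlorine, a methoxy, an amine or a carboxylic acid, would shift the number beyond the scatter, and whether removing the entire outer phenyl ring would do so. They also leave open whether the same exchange of methyl for hydrogen would give a similar result in compound 2 or compound 3, which differ from compound 1 elsewhere in the molecule.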